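Swapping One Side Group: Compound 1 to Compound 3

A few compounds are considered here, and "the series" means these few. Any claim that something is new, unique, unknown or untested is made for them only; others in the source may bear on it.

Measured in an ADME assay (liver) for metabolic stability, with Liver microsome (Rattus norvegicus) as the target, using microsomes and NADPH, with a stated time of 30 min; on this read-out higher numbers stand for fast clearance and lower numbers for slow clearance:
- compound 1 `CC#C[C@H]1CN(S(=O)(=O)c2ccc(N)nc2)CCN1c1ccc([C@@](O)(CO)C(F)(F)F)cc1` gives 53 mL.min-1.g-1
- compound 2 `CC#C[C@H]1CN(S(=O)(=O)c2ccc(N)nc2)CCN1c1ccc(C(C)(O)C(F)(F)F)nc1` gives 31 mL.min-1.g-1

Compound 1 has no separate place on these numbers, as its value and that of compound 2 lie within the usual scatter of each other. Compound 3 `CC#C[C@H]1CN(S(=O)(=O)c2ccc(N)nc2)CCN1c1ccc(S(=O)(=O)Nc2ccccc2)cc1` is still unmeasured. It differs from compound 1 in one place: a group of 10 heavy atoms (6 carbon, 1 nitrogen, 2 oxygen, 1 sulfur; one six-membered aromatic ring of carbon only) in place of a group of 8 heavy atoms (3 carbon, 2 oxygen, 3 fluorine; no ring), on an aromatic carbon. The entering phenylsulfamoyl sits para to a large group. Among the measured compounds shown here, no measured pair differs in one place only, so the data give no direct size for this change. Judging from the structural change alone, a moderate move towards faster clearance, just beyond the scatter, is expected. The expected step is a 2.3-fold higher number from compound 1 to compound 3 (0.35 log units; beyond the scatter). In this assay the estimated value for compound 3 is 120 mL.min-1.g-1, with an expected range from 45 mL.min-1.g-1 to 300 mL.min-1.g-1.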

Compound 3, intrinsic clearance in microsomes: > 399 mL.min-1.g-1
Compound 3: only a limit was reported; the forecaster's own chance of this, stated with the estimate: 10%; middle value at least 3.3-fold (0.52 log units) from the limit.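

Among the compounds shown here, until now no measured pair differed in one place only, so nothing showed how much the group on this aromatic carbon, para to a large group, counts for clearance on the shared core. In this assay, putting phenylsulfamoyl there in place of the group of compound 1 gives an at least 7.5-fold higher number from compound 1 to compound 3 (0.87 log units; beyond the scatter), so this position is clearly not indifferent to the group it carries. The reading for compound 3 is a limit of the assay and not a number, which means the step gives only a lower bound on the change: the limit of > 399 mL.min-1.g-1 in this assay, at which 1 of the 3 values shown sits.

The compounds shown leave open which part of the phenylsulfamoyl goes with this step, and how far compound 3 lies beyond its limit. They also leave open whether a methylsulfonyl group or a carboxylic acid on the same aromatic carbon would stay closer to compound 1.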